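The source may report more compounds than this note shows. Statements on the series, on what has been measured and on what is new or still open speak of the compounds shown alone.

Values measured in a functional assay on MCF7 cells (Homo sapiens) for inhibition, read by sulforhodamine B assay, with a stated time of 48 h, tested at 50 uM (on this read-out lower numbers stand for less inhibition of growth and higher numbers for more inhibition of growth at the one concentration tested), are these:

Compound 1 `Cc1ccc(F)c(C(=O)c2ccc3nc(NC(=O)C(F)(F)F)cn3c2)c1` gives 66.3%
Compound 2 `Cc1ccc(C(=O)c2ccc3nc(NC(=O)C(F)(F)F)cn3c2)cc1F` gives 57.3%
Compound 3 `Cn1cc(C(=O)c2ccc3nc(NC(=O)C(F)(F)F)cn3c2)c2ccccc21` gives 80.4%

Compound 1 holds the second highest of these three numbers. It is level within the scatter with compound 2, while compound 3 stands higher, beyond the scatter. The unmeasured compound 4 `O=C(c1ccc2nc(NC(=O)C(F)(F)F)cn2c1)c1cc(C(F)(F)F)ccc1F` differs from compound 1 in one place: trifluoromethyl in place of methyl on an aromatic carbon, para to a fluoro group (trifluoromethyl in place of methyl on an aromatic carbon). Among the compounds with values here, the one measured step on that ring is a number 9 percentage points lower from compound 1 to compound 2 (within the scatter) and it only rearranges the groups there. Within the data shown here, no measured step replaces the methyl itself, so the evidence is indirect. As far as these compounds go, since that rearrangement stayed within the scatter, no step beyond the scatter is expected in this assay for this change, and the direction remains open. The estimated step is a number 2.3 percentage points lower from compound 1 to compound 4 (within the scatter) on this reasoning. For compound 4 the estimate is 64% and the expected range runs from 48% to 80% in this read-out.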

Compound 4, percent growth inhibition at one concentration: 65.1%
Estimate against measurement, compound 4: 1.1 percentage points below, within the range that was stated.
By their numbers in this assay, from the lowest: compounds 2, 4 and 1 (each within the scatter of the next); then compound 3.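

The earlier compounds shown here only rearranged the groups on this ring, whereas here the methyl itself is replaced. A group of 1 heavy atom gives way to trifluoromethyl with 4 heavy atoms, and in this assay the outcome is a number 1.2 percentage points lower from compound 1 to compound 4 (within the scatter). This position, on an aromatic carbon para to a fluoro group, therefore accepts the larger group with no change that can be told from the scatter, and nothing measured here offers an explanation for this.

As far as these compounds go, whether an amine, a carboxylic acid or a longer chain at this same position would also stay level with compound 1 remains open. Also open, from the compounds shown here alone, is how compound 1 and compound 4 compare at concentrations other than the one tested.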